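This account rests on a few compounds, and the source may have more. Where it says the series, first, only, none or still open, it means among the compounds named here.

Measured compounds:
Compound 1, `O=c1c(-c2nnc(-c3ccc(F)cc3)o2)c[nH]c2ncc(-c3cccnc3)cc12`: in a functional assay on HCT-116 cells (Homo sapiens) for inhibition, read by MTT assay, with a stated time of 24 h, tested at 2.5 uM (a lower number here means less inhibition of growth, a higher number more inhibition of growth at the concentration tested), compound 1 gives 9.87%.
Compound 2, `N#Cc1ccc(-c2cnc3[nH]cc(-c4nnc(-c5ccc(Cl)cc5)o4)c(=O)c3c2)cc1`: in this assay compound 2 gives 13.7%.

Compound 2 holds the higher of the two numbers in this assay, but the gap to compound 1 lies within the usual scatter, so the two compounds cannot be told apart on these data. Both show only weak inhibition of growth at the concentration tested.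

Compound 3, `O=c1c(-c2nnc(-c3ccc(Cl)cc3)o2)c[nH]c2ncc(-c3cccnc3)cc12`, differs from compound 2 in a single place: pyridin-3-yl in place of 4-cyanophenyl on an aromatic carbon. For the measured compounds named here, compound 1 also carries pyridin-3-yl at this position, but it differs from compound 2 in a second place as well, so no pair of measured compounds isolates this one change. What the data show is that both measured compounds, one with pyridin-3-yl and one with 4-cyanophenyl, give low and mutually indistinguishable numbers in this assay.

From that, compound 3 is expected to stay in the same low region, with the step of a number 2.7 percentage points lower from compound 2 to compound 3 (within the scatter) expected to lie within the scatter rather than beyond it. Compound 3 is thus estimated at 11%, in a range from 2% to 22%.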

Compound 3, percent growth inhibition at one concentration: 10.4%
The estimate for compound 3 lay 0.6 percentage points above the measured number; the measured number falls inside the stated range.
By their numbers in this assay, from the lowest: compounds 1, 3 and 2 (each within the scatter of the next).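

With compound 3, the two changes that were tied together in the earlier pair can be read one at a time. In this assay, pyridin-3-yl in place of 4-cyanophenyl on the aromatic carbon gives a number 3.3 percentage points lower from compound 2 to compound 3 (within the scatter), and chloro in place of fluoro on an aromatic carbon gives a number 0.5 percentage points higher from compound 1 to compound 3 (within the scatter), so neither exchange, taken alone, can be told apart from repeat scatter at the concentration tested. No data are available that would explain these results.

The compounds shown leave open whether a substituent of a different kind on this aromatic carbon, such as an aminomethyl group or a carboxylic acid in place of the aromatic rings seen so far, would give a number that stands clear of the scatter. From the compounds shown here alone, it also remains open whether anything other than a halogen on the far phenyl ring, such as a methoxy group or a dimethylamino group, would separate from these three compounds in this assay.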